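The compounds below may be only part of what the source reports. "The series", "measured", "known", "first", "only" and "open" are said of these compounds alone.

Three compounds have been measured so far in an ADME assay on HEK293 cells (Homo sapiens) for cytotoxicity, read by MTT assay, with a stated time of 48 h (a higher number here means a weaker inhibitor, a lower number a stronger inhibitor), as follows:
- compound 1 `O=C1CS/C(=N/c2ccccc2)N1Cc1ccncc1` gives 99500 nM
- compound 2 `Cc1ccc(/C=C2/S/C(=N/c3ccccc3)N(Cc3ccncc3)C2=O)cc1` gives 49500 nM
- compound 3 `O=C1/C(=C\c2ccc([N+](=O)[O-])cc2)S/C(=N/c2ccccc2)N1Cc1ccncc1` gives 250000 nM

Compound 3 stands highest of the three, clear of the scatter from both compound 1 and compound 2. In compound 4 `CCOc1cc(/C=C2/S/C(=N/c3ccccc3)N(Cc3ccncc3)C2=O)ccc1O` the change is 3-ethoxy-4-hydroxyphenyl in place of 4-nitrophenyl on a double-bonded chain carbon bound to a double-bonded ring carbon and, in words, 3-ethoxy-4-hydroxyphenyl in place of 4-nitrophenyl on a double-bonded chain carbon bound to a double-bonded ring carbon. Going by the values given here, the one measured step that bears on this is a 5.1-fold higher number from compound 2 to compound 3 (0.70 log units; beyond the scatter) and it is modest, with the nitro group on the higher side. Compound 4 also lacks the nitro group, so a modest step towards a lower number in this assay is expected, of similar or smaller size. Among the compounds with values here, this expectation remains loose, since no measured compound carries the new group. The expected change is a 2.8-fold lower number from compound 3 to compound 4 (0.44 log units; beyond the scatter) in this estimate. The estimate for compound 4 is 90000 nM with 35000 nM to 220000 nM as its expected range.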

Compound 4, half-maximal inhibitory concentration: 46500 nM
Compound 4: middle estimate off by 1.9-fold (0.29 log units), on the high side; the range from low to high includes it.
By their numbers in this assay, from the lowest: compounds 4, 2 and 1 (each within the scatter of the next, the first and the last beyond it); then compound 3.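

In this assay, 3-ethoxy-4-hydroxyphenyl in place of 4-nitrophenyl on a double-bonded chain carbon bound to a double-bonded ring carbon gives a 5.4-fold lower number from compound 3 to compound 4 (0.73 log units; beyond the scatter) at this place, so a second group now lies clearly on the lower side of the 4-nitrophenyl of compound 3. The assay does not tell the two non-nitro groups apart, since 3-ethoxy-4-hydroxyphenyl in place of 4-methylphenyl gives a 1.1-fold lower number from compound 2 to compound 4 (0.03 log units; within the scatter) and the larger group brings no change beyond the scatter. Nothing measured here explains why compound 3 stands apart.

The compounds shown leave open whether another group on this phenyl ring, such as an amine or a carboxylic acid, would fall with compound 3 or with compound 2 and compound 4. They also leave open whether a nitrile would behave as the nitro group does.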